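Pyrrolidine nitrogen substituent: acyl to methyl

A few compounds are considered here, and "the series" means these few. Any claim that something is new, unique, unknown or untested is made for them only; others in the source may bear on it.

Measured compounds:
compound 1 `CC(C)(C)OC(=O)N1C(=O)CC[C@H]1C(=O)N1CCC(NS(=O)(=O)c2cc(S(=O)(=O)c3ccccc3)ccc2C(F)(F)F)CC1` — 90 nM
compound 2 `CC(C)(C)CC(=O)N1CCC[C@H]1C(=O)N1CCC(NS(=O)(=O)c2cc(S(=O)(=O)c3ccccc3)ccc2C(F)(F)F)CC1` — 120 nM
compound 3 `CC(C)(C)NC(=O)N1CCC[C@H]1C(=O)N1CCC(NS(=O)(=O)c2cc(S(=O)(=O)c3ccccc3)ccc2C(F)(F)F)CC1` — 30 nM

Within the data shown here, in a functional assay on U2OS cells for antagonist activity at proto-oncogene Wnt-3 (Homo sapiens), read by a luciferase reporter, with a stated time of 18 h (a lower number here means that less compound is needed, a higher number that more compound is needed for the effect), compound 2 gives the highest number of the three; compound 1 sits nearest, within the scatter, and compound 3 furthest, with a 4.0-fold lower number from compound 2 to compound 3 (0.60 log units; beyond the scatter) the only step beyond the scatter among them.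

Compound 4 `CN1CCC[C@H]1C(=O)N1CCC(NS(=O)(=O)c2cc(S(=O)(=O)c3ccccc3)ccc2C(F)(F)F)CC1` is not yet measured. It differs from compound 2 by methyl in place of neopentylcarbonyl on an amine nitrogen in a ring. Among the measured compounds shown here, the only measured step touching this nitrogen, a 4.0-fold lower number from compound 2 to compound 3 (0.60 log units; beyond the scatter), keeps a carbonyl on it and exchanges one group on that carbonyl for another; none of the measured compounds lacks the carbonyl on that ring nitrogen, so no step bears directly on the change to compound 4. All three measured compounds carry a carbonyl there, and the expectation for removing it rests on nothing closer than that. A step of a 3.3-fold higher number from compound 2 to compound 4 (0.52 log units; beyond the scatter) toward a higher number in this assay is expected for compound 4, with wide uncertainty. The estimate for compound 4 is 400 nM, in a range from 80 nM to 3000 nM.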

Compound 4, half-maximal effective concentration: 230 nM
For compound 4 the middle estimate is 1.7-fold (0.24 log units) above the measured one; measured number inside the range.
By their numbers in this assay, from the lowest: compound 3; then compounds 1, 2 and 4 (each within the scatter of the next, the first and the last beyond it).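

In this assay, a carbonyl on the amine nitrogen in the ring is not needed to stay within the scatter of compound 2: the series shows a 1.9-fold higher number from compound 2 to compound 4 (0.28 log units; within the scatter) even though neopentylcarbonyl, with 7 heavy atoms, gives way to methyl, with 1. Replacing (tert-butyl)carbamoyl at the same nitrogen gives a clear loss, with a 7.7-fold higher number from compound 3 to compound 4 (0.88 log units; beyond the scatter), so the effect of going to methyl depends on which carbonyl group it replaces in these two pairs. No evidence is available to account for the difference between the two steps.

Still open, from the compounds shown here alone, is how this assay reads the same nitrogen bearing only hydrogen, or an ethyl or benzyl group. Also open, going by these compounds, is whether methylcarbamoyl in place of (tert-butyl)carbamoyl would stay within the scatter of compound 3.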